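Cyano in place of phenyl: the step to compound 4

The compounds below may be only part of what the source reports. "The series", "measured", "known", "first", "only" and "open" are said of these compounds alone.

Measured in a functional assay on Jurkat cells (Homo sapiens); a lower number here means a stronger inhibitor, a higher number a weaker inhibitor:
Compound 1 `CC(C)[C@H](NC(=O)COc1cccc2ccccc12)C(=O)N[C@@H](CC(=O)O)C(=O)COc1ccc2ccccc2c1`: > 100000 nM, a limit of the assay
Compound 2 `CC(C)[C@H](NC(=O)COc1cccc2ccccc12)C(=O)N[C@@H](CC(=O)O)C(=O)COc1ccc(-c2ccccc2)cc1`: 87900 nM
Compound 3 `CC(C)[C@H](NC(=O)COc1cccc2ccccc12)C(=O)N[C@@H](CC(=O)O)C(=O)COc1cc(C(F)(F)F)cc(C(F)(F)F)c1`: > 100000 nM, a limit of the assay

Among the measured compounds shown here, compound 2, at 87900 nM, is the only compound here with an actual number. The other two sit at the limit of > 100000 nM in this assay, at which 2 of the 3 values shown sit.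

Compound 4 `CC(C)[C@H](NC(=O)COc1cccc2ccccc12)C(=O)N[C@@H](CC(=O)O)C(=O)COc1ccc(C#N)cc1` has cyano in place of phenyl on an aromatic carbon, para to a large group: cyano in place of phenyl on an aromatic carbon.

For the measured compounds named here, one measured step bears on this change, a swap of the group on the same oxygen: an at least 1.1-fold lower number from compound 1 to compound 2 (0.05 log units; that floor lies within the scatter). Going by the values given here, with only that step to go on, no change beyond the scatter is expected in this assay, and the expected step is a 1.0-fold higher number from compound 2 to compound 4 (0.01 log units; within the scatter).

Compound 4 is estimated at 90000 nM, with an expected range of 35000 nM to 180000 nM.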

Compound 4, half-maximal inhibitory concentration: > 100000 nM
Compound 4: a limit, no number; the forecaster's own chance of this, stated with the estimate: 55%; at least 1.1-fold (0.04 log units) between middle value and limit.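

In this assay compound 4 gives > 100000 nM, which is a limit of the assay and not a number. Cyano in place of phenyl on this aromatic carbon gives an at least 1.1-fold higher number from compound 2 to compound 4 (0.05 log units; that floor lies within the scatter), so the floor of this step stays within the scatter and compound 2 remains the only compound with a number, while the step between the two limits cannot be read. With compound 4, the limit now holds most of the series: the limit of > 100000 nM in this assay, at which 3 of the 4 values shown sit.

As far as these compounds go, how far compound 4 lies past its limit stays open. So does whether an amine, a carboxylic acid or a methoxy group at this place would give a number.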